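The source may report more compounds than this note shows. Statements on the series, on what has been measured and on what is new or still open speak of the compounds shown alone.

Measured compounds:
compound 1 `ClCc1ccc(Cn2cnc3c(Cl)ncnc32)cc1`, in a functional assay on MDA-MB-435 cells (Homo sapiens) for cytotoxicity, read by sulforhodamine B assay, with a stated time of 48 h (a lower number here means a stronger inhibitor of growth, a higher number a weaker inhibitor of growth), 1620 nM
compound 2 `Nc1nc(Cl)c2ncn(Cc3ccc(CCl)cc3)c2n1`, 16600 nM

In this assay, within the data shown here, compound 2 holds the higher of the two numbers, and the single step that reaches it, a 10-fold higher number from compound 1 to compound 2 (1.01 log units; beyond the scatter), is large and beyond the scatter. Compound 3 `ClCc1ccc(Cn2cnc3c(Cl)nc(Cl)nc32)cc1` is not yet measured; it differs from compound 2 by chloro in place of amino on an aromatic carbon. The amino that compound 2 carries is removed, so the same a 10-fold higher number from compound 1 to compound 2 (1.01 log units; beyond the scatter) bears on this step, read in reverse; a chloro rather than a hydrogen takes the place, so the return need not be complete. Compound 3 is therefore expected to come in lower, with a 6.6-fold lower number from compound 2 to compound 3 (0.82 log units; beyond the scatter). For compound 3 the estimate is 2500 nM, within 800 nM to 8000 nM.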

Compound 3, concentration for 50% growth inhibition: 12600 nM
Estimate against measurement, compound 3: 5.0-fold (0.70 log units) below, outside the stated range (above it).
By their numbers in this assay, from the lowest: compound 1; then compounds 3 and 2 (each within the scatter of the next).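

At this place, between two ring nitrogen atoms, amino and chloro are not told apart in this assay: the step is a 1.3-fold lower number from compound 2 to compound 3 (0.12 log units; within the scatter). Compound 1, with hydrogen there, stands apart from both, with a 7.8-fold higher number from compound 1 to compound 3 (0.89 log units; beyond the scatter) alongside a 10-fold higher number from compound 1 to compound 2 (1.01 log units; beyond the scatter), so the large step seen earlier is not particular to amino. No measurement on hand offers an explanation for this. On these data alone, whether a methyl or methoxy group at this place would read with hydrogen or with amino and chloro stays open.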